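Acetyl in Place of Methylsulfonyl: Compound 3 Foreseen

The compounds below may be only part of what the source reports. "The series", "measured", "known", "first", "only" and "open" are said of these compounds alone.

Compound 1 `O=C(Nc1ccc2c(c1)CC(NS(=O)(=O)c1ccccc1)C2)c1ccccc1-c1ccccc1` gives 12 nM in an assay for inhibition of apolipoprotein B-100 (Homo sapiens), tested at 100 nM; a lower number here means a stronger inhibitor, a higher number a weaker inhibitor. Within the data shown here, compound 2 `CS(=O)(=O)NC1Cc2ccc(NC(=O)c3ccccc3-c3ccc(C(F)(F)F)cc3)cc2C1` gives 60 nM in this assay; of the two numbers known so far, compound 2 holds the higher one, and its gap to compound 1 lies beyond the usual scatter. Compound 3 `CC(=O)NC1Cc2ccc(NC(=O)c3ccccc3-c3ccc(C(F)(F)F)cc3)cc2C1` has not yet been measured. It differs from compound 2 in a single place: acetyl in place of methylsulfonyl on an amine nitrogen. Among the measured compounds shown here, no pair of measured compounds shows this exchange, so its size can only be judged from the change itself. Compound 3 is expected to stand close to compound 2 in this assay, the step of a 1.7-fold higher number from compound 2 to compound 3 (0.22 log units; within the scatter) being estimated as small and, if anything, toward a weaker inhibitor. The estimate for compound 3 in this assay is therefore 100 nM, with a range from 30 nM to 350 nM.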

Compound 3, half-maximal inhibitory concentration: 120 nM
For compound 3 the middle estimate is 1.2-fold (0.08 log units) below the measured one, and the stated range covers the measured number.
By their numbers in this assay, from the lowest: compound 1; then compounds 2 and 3 (each within the scatter of the next).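

Acetyl in place of methylsulfonyl on the amine nitrogen gives a 2.0-fold higher number from compound 2 to compound 3 (0.30 log units; within the scatter) in this assay, the first reading of any single change at this position. On this shared core, then, the methanesulfonamido group can be exchanged for acetamido, with one fewer heavy atom and one fewer hydrogen-bond acceptor, without a difference that can be told from the scatter. Nothing measured here accounts for this result.

On these data alone, whether the exchange reads the same when the nitrogen carries the group found in compound 1 remains open, as this single pair cannot show it. Also open, as far as these compounds go, is how this position would respond to a longer chain such as propanoyl, to a urea, or to a free amine on the same nitrogen.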